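Furan-2-yl to 1,3-oxazol-5-yl: an expected small step

The source may hold more compounds than are shown below. What is called first, only, known or untested is meant among the compounds shown, and "the series" means these compounds.

Two compounds have so far been measured in an assay on HEK293 cells for displacement of a labelled ligand from growth hormone secretagogue receptor type 1 (Homo sapiens), with a stated time of 60 min; a lower number here means a stronger inhibitor, a higher number a weaker inhibitor:

Compound 1: `COc1cccc(-n2cc3nc(-c4cccnc4C)n(C[C@H]4CCCN(Cc5ccco5)C4)c(=O)c3n2)c1` gives 2.7 nM
Compound 2: `COc1cccc(-n2cc3nc(-c4ccccc4C)n(CC4CCCN(C(C)C)C4)c(=O)c3n2)c1` gives 1.8 nM

Compound 1 has the higher of the two numbers, but the gap to compound 2 is within the usual scatter of this assay, so the two cannot be told apart on these data. Within the data shown here, compound 1 and compound 2 also differ in several places at once, so no single-change step between measured compounds is available to lean on.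

Compound 3, `COc1cccc(-n2cc3nc(-c4cccnc4C)n(C[C@H]4CCCN(Cc5cnco5)C4)c(=O)c3n2)c1`, differs from compound 1 in exactly one place: 1,3-oxazol-5-yl in place of furan-2-yl on a saturated chain carbon bound to an amine nitrogen in a ring. The group that leaves and the group that enters are both five-membered aromatic rings of five heavy atoms, sitting on a saturated chain carbon bound to an amine nitrogen in a ring.

Among the measured compounds shown here, with no measured step to guide the size, the step of a 1.3-fold higher number from compound 1 to compound 3 (0.11 log units; within the scatter) is expected to be small, with no change beyond the scatter in either direction. Compound 3 is therefore estimated at 3.5 nM in this assay, with a range from 1.2 nM to 10 nM.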

Compound 3, half-maximal inhibitory concentration: 120 nM
Compound 3: middle estimate off by 34-fold (1.54 log units), on the low side; the measured number lies above the stated range.
By their numbers in this assay, from the lowest: compounds 2 and 1 (each within the scatter of the next); then compound 3.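

In this assay the exchange of furan-2-yl for 1,3-oxazol-5-yl on a saturated chain carbon bound to an amine nitrogen in a ring gives a 44-fold higher number from compound 1 to compound 3 (1.65 log units; beyond the scatter) and so shows that this place responds strongly to a change within the ring itself. The two rings are both five-membered and aromatic, with 5 heavy atoms and no net charge, yet they are not interchangeable here, and the visible differences are that the entering ring has 1 nitrogen and 2 hydrogen-bond acceptors where the leaving ring has no nitrogen and 1 hydrogen-bond acceptor. No measurement available here explains why the number rises so far.

Still open, on these data alone, is whether the large step belongs to 1,3-oxazol-5-yl alone or would also appear with other rings at this place, such as thiophen-2-yl, 1,3-oxazol-2-yl or 1,3-thiazol-5-yl. A plain phenyl ring on the same chain carbon would also help to show whether furan-2-yl is unusually well suited to this place or whether 1,3-oxazol-5-yl is unusually poorly suited.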